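This account rests on a few compounds, and the source may have more. Where it says the series, first, only, none or still open, it means among the compounds named here.

Compound 1 `COc1cc(-c2nn(-c3cccc(NC(=O)Nc4ccc(Cl)c(Cl)c4)c3)cc2-c2ccncc2)ccc1Cl` carries a methoxy group on its chloro-substituted aryl ring and a 3,4-dichlorophenyl urea. In a functional assay on SF-539 cells (Homo sapiens) for inhibition, read by sulforhodamine B assay, with a stated time of 48 h (a higher number here means a weaker inhibitor of growth, a lower number a stronger inhibitor of growth), compound 1 gives 3080 nM, the second highest of the three numbers. Compound 2 `O=C(Nc1cccc(-n2cc(-c3ccncc3)c(-c3ccc(Cl)c(O)c3)n2)c1)Nc1ccc(Cl)c(Cl)c1`, differing only by a hydroxyl in place of the methoxy, gives 8970 nM in this assay, and the step of a 2.9-fold higher number from compound 1 to compound 2 (0.46 log units; beyond the scatter) lies beyond the scatter. Compound 3 `O=C(Nc1cccc(-n2cc(-c3ccncc3)c(-c3ccc(Cl)c(O)c3)n2)c1)Nc1cc(C(F)(F)F)cc(C(F)(F)F)c1` gives 1490 nM, the lowest of the three.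

Compound 4 `COc1cc(-c2nn(-c3cccc(NC(=O)Nc4ccc(Cl)c(C(F)(F)F)c4)c3)cc2-c2ccncc2)ccc1Cl` is compound 1 with trifluoromethyl in place of chloro on an aromatic carbon. Within the data shown here, no measured step changes only this position. Among the measured compounds shown here, the single measured step, from the methoxy to the hydroxyl, concerns a different part of the molecule and says nothing about the urea aryl. The values of compound 2 and compound 3 show that a urea aryl carrying trifluoromethyl groups instead of chlorines gives a lower number, but that pair differs in more than one place. A modest lowering is therefore expected, and compound 4 is estimated at 2000 nM (range 800 nM to 5000 nM), a step of a 1.5-fold lower number from compound 1 to compound 4 (0.19 log units; within the scatter).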

Compound 4, concentration for total growth inhibition: 6340 nM
The estimate for compound 4 lay 3.2-fold (0.50 log units) below the measured number; the whole stated range lies below it.
By their numbers in this assay, from the lowest: compound 3; then compound 1; then compounds 4 and 2 (each within the scatter of the next).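

Among these compounds, compound 4 gives the first reading of a single change on the urea aryl ring: going from 3,4-dichlorophenyl to 4-chloro-3-(trifluoromethyl)phenyl in this assay gives a 2.1-fold higher number from compound 1 to compound 4 (0.31 log units; beyond the scatter) and so makes a weaker inhibitor of growth. With the methoxy group and the rest of the molecule held constant, this position therefore responds to trifluoromethyl in place of chloro, although the step is modest and rests on this one pair. No measurement offered here explains the rise.

As far as these compounds go, it remains open whether the same replacement would raise the number in the hydroxyl compound 2, where the surrounding molecule differs. Also open, from the compounds shown here alone, is how a methyl, an amine or a carboxylic acid on this aromatic carbon would compare with chloro and trifluoromethyl.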